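A few compounds are considered here, and "the series" means these few. Any claim that something is new, unique, unknown or untested is made for them only; others in the source may bear on it.

Measured compounds:
compound 1 `FC(F)(F)c1ccc(COc2ccccc2Nc2ncnc3cc4c(cc23)OCCOCCOCCO4)cc1` – > 100000 nM
compound 2 `FC(F)(F)c1ccc(COc2cccc(Nc3ncnc4cc5c(cc34)OCCOCCO5)c2)cc1` – > 100000 nM

In a functional assay on A549 cells (Homo sapiens) for antiproliferative activity, read by MTT assay, with a stated time of 72 h (a lower number here means a stronger inhibitor, a higher number a weaker inhibitor), compound 1 reaches only the limit of the assay, > 100000 nM. In this assay, within the data shown here, compound 2 likewise stands at a limit, > 100000 nM, so no number is known for it, and it shares that position with the one other value shown (the limit of > 100000 nM in this assay, at which 2 of the 2 values shown sit). Compound 3 `O=[N+]([O-])c1ccc(COc2cccc(Nc3ncnc4cc5c(cc34)OCCOCCO5)c2)cc1` carries nitro in place of trifluoromethyl on an aromatic carbon. Among the measured compounds shown here, with no measured step of this kind to lean on, the account expects no change beyond the scatter, and it treats a further limit as the likeliest outcome. The estimated step of a number no higher from compound 2 to compound 3 (the limit leaves the size open) is therefore flat, and compound 3 is expected at 100000 nM, within 20000 nM to 500000 nM.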

Compound 3, half-maximal inhibitory concentration: 15500 nM
Compound 3: middle estimate off by 6.5-fold (0.81 log units), on the high side, and the stated range ends above it.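

In this assay, among these compounds, the earlier compounds gave only limits, whereas nitro in place of trifluoromethyl gives a measurable number, with an at least 6.4-fold lower number from compound 2 to compound 3 (0.80 log units; beyond the scatter). This shows, for this one pair, that the group on this aromatic carbon can shift the read-out. Compound 2 stands at a limit, so the true size of the step stays open: the limit of > 100000 nM in this assay, at which 2 of the 3 values shown sit.

On these data alone, whether an amine or a carboxylic acid on the same carbon would lower the number further remains open. So does whether nitro would give a similar step on the core of compound 1.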